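Methylsulfanyl in Place of Methoxy: Inactivity Expected to Persist

The source may hold more compounds than are shown below. What is called first, only, known or untested is meant among the compounds shown, and "the series" means these compounds.

Three measured compounds share one core: compound 1 `COc1ccccc1CNC(=O)SC[C@H](NC(C)=O)C(=O)O`, compound 2 `COc1ccccc1NC(=O)SC[C@H](NC(C)=O)C(=O)O` and compound 3 `COc1ccc(OC)c(NC(=O)SC[C@H](NC(C)=O)C(=O)O)c1`. In a functional assay on UACC-62 cells (Homo sapiens) for cytotoxicity, read by MTT assay, with a stated time of 6 days (a higher number here means a weaker inhibitor, a lower number a stronger inhibitor), compound 1 gives only a limit, > 200000 nM. In this assay compound 2 likewise reaches no number but the limit > 200000 nM. Compound 3 also stands at a limit in this assay, > 200000 nM. Among the compounds with values here, compound 2 therefore stands where every value here stands, at the limit of > 200000 nM in this assay, at which 3 of the 3 values shown sit, and the single step among the measured compounds, a step that the two limits leave unreadable from compound 2 to compound 3, cannot be sized. Compound 4 `CSc1ccccc1NC(=O)SC[C@H](NC(C)=O)C(=O)O` differs from compound 2 by methylsulfanyl in place of methoxy on an aromatic carbon. Within the data shown here, no measured step bears on this change, since the only one available, a step that the two limits leave unreadable from compound 2 to compound 3, is unreadable. Nothing in the measured data points to a step in this assay beyond the scatter, so the expected step that the limit leaves unreadable from compound 2 to compound 4 is no more than a cautious guess. Compound 4 is expected to give about 300000 nM in this assay, within 100000 nM to 1000000 nM, most probably again reported only as a limit.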

Compound 4, half-maximal inhibitory concentration: > 200000 nM
Compound 4: no number, only a limit (the forecaster's own chance of this, stated with the estimate: 85%); the middle value lies beyond the limit too.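

In this assay, within the data shown here, compound 4 also gives only a limit, > 200000 nM, so no step from compound 2 to compound 4 can be read. The compounds shown leave open whether any change on the shared core would give a readable value in this assay, for all of them stand at one limit: the limit of > 200000 nM in this assay, at which 4 of the 4 values shown sit.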